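Bromo in place of nitro in a small series

A few compounds are considered here, and "the series" means these few. Any claim that something is new, unique, unknown or untested is made for them only; others in the source may bear on it.

In a functional assay on B16-F10 cells (Mus musculus) for antiproliferative activity, read by MTT assay, with a stated time of 48 h (on this read-out higher numbers stand for weaker inhibition and lower numbers for stronger inhibition), compound 1 (`O=C(/C=C/c1ccc(Br)cc1)Nc1cc(-c2ccc(Br)cc2)[nH]n1`) gives 1280 nM and compound 2 (`O=C(/C=C/c1ccc([N+](=O)[O-])cc1)Nc1cc(-c2ccccc2)[nH]n1`) gives 720 nM as its result. These two numbers lie within the scatter of each other, so neither compound can be placed ahead of the other. Compound 3 (`O=C(/C=C/c1ccc(Br)cc1)Nc1cc(-c2ccccc2)[nH]n1`) has not been measured yet. It differs from compound 2 in one place, with bromo in place of nitro on an aromatic carbon and the rest of the structure unchanged. For the measured compounds named here, no measured pair shows this swap on its own, so the size of its effect cannot be read directly from the data. The estimated step of a 1.4-fold higher number from compound 2 to compound 3 (0.14 log units; within the scatter) is expected to lean slightly toward a higher number and to stay within the scatter. For compound 3 the expected value is 1000 nM with a likely range from 450 nM to 2200 nM once it is tested.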

Compound 3, half-maximal inhibitory concentration: 1380 nM
Compound 3: the middle estimate sits 1.4-fold (0.14 log units) below what was measured, within the range that was stated.
By their numbers in this assay, from the lowest: compounds 2, 1 and 3 (each within the scatter of the next).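

In this assay, the swap of nitro for bromo, on a six-membered aromatic ring of carbon only and para to a large group, can now be read on its own. The step is a 1.9-fold higher number from compound 2 to compound 3 (0.28 log units; within the scatter) and so shows no readable difference, even though three heavy atoms leave and one enters. The same holds for hydrogen in place of bromo on an aromatic carbon, where the step is a 1.1-fold higher number from compound 1 to compound 3 (0.03 log units; within the scatter) and no measurement at hand explains either result.

As far as these compounds go, whether a different group at the place that held nitro, such as an amine or a carboxylic acid, would give a step beyond the scatter remains open. With so few single changes, the compounds shown also cannot tell which parts of the shared core matter for this activity.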